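The source may hold more compounds than are shown below. What is called first, only, known or untested is meant among the compounds shown, and "the series" means these compounds.

Compound 1 `CC(=O)OC1C(CN=[N+]=[N-])OC(n2c(Cl)nc3cc(Cl)c(Cl)cc32)C1OC(C)=O`: 32000 nM
Compound 2 `O[C@@H]1[C@@H](CF)OC(n2c(Cl)nc3cc(Cl)c(Cl)cc32)[C@@H]1O`: 32000 nM

In a functional assay on HFF cells (Homo sapiens) for cytotoxicity (a higher number here means a weaker inhibitor, a lower number a stronger inhibitor), compound 2 gives 32000 nM and stands level with compound 1 (32000 nM), within the scatter. Compound 3 `[N-]=[N+]=NC[C@H]1OC(n2c(Cl)nc3cc(Cl)c(Cl)cc32)[C@H](O)[C@@H]1O` differs from compound 2 in one place (azido in place of fluoro on a saturated chain carbon bound to a saturated ring carbon), with azido in place of fluoro on a saturated chain carbon bound to a saturated ring carbon. For the measured compounds named here, no measured step shows this change directly. Compound 1 also carries azidomethyl and gives 32000 nM in this assay, so no shift beyond the scatter is expected in either direction. The expected step is small (no change at the digits printed from compound 2 to compound 3 (within the scatter)). The estimate for compound 3 is 32000 nM, with an expected range from 10000 nM to 100000 nM.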

Compound 3, half-maximal inhibitory concentration: 32000 nM
Compound 3: middle estimate and measured number agree at the digits printed, within the range that was stated.
By their numbers in this assay, from the lowest: compounds 1, 2 and 3 (each within the scatter of the next).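

In this assay, for the compounds shown here, replacing fluoromethyl with azidomethyl on a saturated chain carbon bound to a saturated ring carbon gives no change at the digits printed from compound 2 to compound 3 (within the scatter) in the first pair to isolate this change. At this position, then, the larger azido group, with its three nitrogen atoms, leaves the read-out level with the single fluorine atom it replaces.

The compounds shown leave open whether an amine, a hydroxyl or a longer alkyl chain at this position would also read level. No supporting measurement bears on this result.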